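Compound 3: what follows when the chloro leaves compound 2

A few compounds are considered here, and "the series" means these few. Any claim that something is new, unique, unknown or untested is made for them only; others in the source may bear on it.

In a functional assay on HCT-116 cells (Homo sapiens) for cytotoxicity, read by resazurin assay, with a stated time of 48 h (on this read-out higher numbers stand for an effect only at larger amounts of compound and lower numbers for an effect already at smaller amounts), compound 1 (`COc1ccc(S(=O)(=O)Nc2ccc(-c3nc4cc(NS(=O)(=O)c5ccc(OC)cc5)ccc4o3)cc2)cc1`) gives 12000 nM and compound 2 (`O=C(Nc1ccc(Sc2nc3ccccc3s2)c(Cl)c1)c1cccc(Br)c1O`) gives 12000 nM as well, so compound 2 stands level with compound 1, within the scatter. For the measured compounds named here, no measured step joins these two compounds in one place. Compound 3 (`O=C(Nc1ccc(Sc2nc3ccccc3s2)cc1)c1cccc(Br)c1O`) has not yet been measured. It differs from compound 2 by hydrogen in place of chloro on an aromatic carbon. Going by the values given here, with no measured step of this kind to go by, no shift beyond the scatter is expected in this assay, with only a slight lean towards higher numbers. This expectation starts from compound 2 at 12000 nM and carries wide uncertainty. The expected 1.3-fold higher number from compound 2 to compound 3 (0.10 log units; within the scatter) is estimated to stay within the scatter. For compound 3 the estimated value is 15000 nM with an expected lower end (6000 nM) and upper end (40000 nM).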

Compound 3, half-maximal effective concentration: 8900 nM
For compound 3 the middle estimate is 1.7-fold (0.23 log units) above the measured one, and the stated range covers the measured number.
By their numbers in this assay, from the lowest: compounds 3, 1 and 2 (each within the scatter of the next).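

For the compounds shown here, with compound 2 and compound 3, a change at a single place can be read for the first time in this assay: hydrogen in place of chloro on an aromatic carbon, ortho to a large group and meta to a large group, gives a 1.3-fold lower number from compound 2 to compound 3 (0.13 log units; within the scatter) at this position. In this pair, the chloro can therefore leave without a shift beyond the scatter, so this one chlorine atom is not needed to keep the read-out at this level. Nothing available explains this outcome.

The compounds shown leave open whether a fluoro, a methyl or a methoxy on this same aromatic carbon would also stay within the scatter. They also leave open whether an amine or a carboxylic acid there would move the number beyond it.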